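Swapping an Aminoacyl Arm for a Methanesulfonamide Chain

A few compounds are considered here, and "the series" means these few. Any claim that something is new, unique, unknown or untested is made for them only; others in the source may bear on it.

Measured so far:
compound 1 `COc1cc(N)c(Cl)cc1C(=O)NC1CCN(C(=O)C2CCN(C(=O)CCCN)CC2)CC1` gives 425 nM
compound 2 `CCCC(N)C(=O)N1CCC(CN2CCC(NC(=O)c3cc(Cl)c(N)cc3OC)CC2)CC1` gives 2.57 nM
compound 3 `COc1cc(N)c(Cl)cc1C(=O)NC1CCN(CC2CCN(C(=O)CCN)CC2)CC1` gives 9.5 nM

These three compounds share a core and were tested in an assay on striatum for inhibition of 5-hydroxytryptamine receptor 4 (Cavia porcellus), read by radioligand binding; a lower number here means a stronger inhibitor, a higher number a weaker inhibitor. Compound 2 gives the lowest number of the three, with compound 3 the nearest and compound 1 the furthest away. Among the compounds with values here, the one step between neighbours that differ in a single place, a 3.7-fold higher number from compound 2 to compound 3 (0.57 log units; beyond the scatter), shows that changing the group on the carbonyl carbon of the arm already moves the number by a modest amount.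

Compound 4 `COc1cc(N)c(Cl)cc1C(=O)NC1CCN(CC2CCN(CCCNS(C)(=O)=O)CC2)CC1` has not been measured yet. It differs from compound 2 in one place: 3-(methanesulfonamido)propyl in place of (1-aminobutyl)carbonyl on an amine nitrogen in a ring. This is a larger change than the step from compound 2 to compound 3, since the carbonyl is gone and the group that enters is built quite differently, with a sulfur atom and two oxygens in place of the carbonyl.

Within the data shown here, only the step from compound 2 to compound 3 bears on this, and it points to a higher number when the arm is altered. Because of a 3.7-fold higher number from compound 2 to compound 3 (0.57 log units; beyond the scatter) and the larger change here, compound 4 is expected to give a higher number, estimated as a 12-fold higher number from compound 2 to compound 4 (1.07 log units; beyond the scatter). The estimate for compound 4 is 30 nM, in the range 8 nM to 120 nM.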

Compound 4, half-maximal inhibitory concentration: 21.1 nM
For compound 4 the middle estimate is 1.4-fold (0.15 log units) above the measured one, and the stated range covers the measured number.
By their numbers in this assay, from the lowest: compound 2; then compound 3; then compound 4; then compound 1.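

In this assay, the earlier step changed only the group attached to the carbonyl, whereas this result tests the ring nitrogen with no carbonyl on it at all, and the cost is an 8.2-fold higher number from compound 2 to compound 4 (0.91 log units; beyond the scatter). Set against the shorter aminoacyl arm, the same replacement gives a 2.2-fold higher number from compound 3 to compound 4 (0.35 log units; beyond the scatter), which is a smaller step but still beyond the scatter, so both aminoacyl arms give lower numbers than the 3-(methanesulfonamido)propyl chain. Nothing measured here explains why the number moves in either step.

Because the carbonyl and the free amine leave together, these compounds cannot show which loss matters, or what the methanesulfonamide itself contributes; a plain 3-aminopropyl chain and a 3-acetamidopropyl chain on the same ring nitrogen would help to separate these changes. On these data alone, the length of the chain also remains open, since a 4-(methanesulfonamido)butyl chain or a 2-(methanesulfonamido)ethyl chain could show whether the distance from the ring to the methanesulfonamide affects the number.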